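Working notes: from compound 1 to compound 4

The source may report more compounds than this note shows. Statements on the series, on what has been measured and on what is new or still open speak of the compounds shown alone.

Three compounds of the series have a reading in an ADME assay on microsomes from liver (Homo sapiens) for metabolic stability, read by LC-MS, using NADPH, with stated times of 5 min and 30 min, tested at 1 uM; on this read-out lower numbers stand for slow clearance and higher numbers for fast clearance. Compound 1 (`Cn1cc(-c2cnc(NCc3c(F)ccc4c3CCO4)c3cn[nH]c(=O)c23)cn1`) gives 21 mL.min-1.g-1. Compound 3 (`Cc1ncccc1-c1cnc(NCc2c(F)ccc3c2CCO3)c2ncc(=O)[nH]c12`) gives 21 mL.min-1.g-1, which leaves compound 1 level with it, within the scatter. Compound 2 (`C[C@@H]1CC(=O)N(c2cnc(NCc3c(F)ccc4c3CCO4)n3cnnc23)C1`) reads < 3 mL.min-1.g-1, and this is a limit of the assay and not a number. Going by the values given here, compound 1 therefore has one numerical neighbour, and the only other reading offers no exact gap to measure.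

The next compound is compound 4 (`CN(C)C(=O)c1cc(-c2cnc(NCc3c(F)ccc4c3CCO4)c3cn[nH]c(=O)c23)n(C)n1`). It keeps the core of compound 1 and carries 3-(dimethylcarbamoyl)-1-methyl-1H-pyrazol-5-yl in place of 1-methyl-1H-pyrazol-4-yl on an aromatic carbon. The new group keeps one five-membered aromatic ring with 2 hetero atoms and has no net charge.

Among the compounds with values here, no measured pair isolates a change at this place, and the expectation is correspondingly loose. A small step towards slower clearance is expected in this assay, within the scatter. The estimated step is a 1.5-fold lower number from compound 1 to compound 4 (0.18 log units; within the scatter). For compound 4 the estimated value is 14 mL.min-1.g-1, with an expected range from 5 mL.min-1.g-1 to 35 mL.min-1.g-1.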

Compound 4, intrinsic clearance in microsomes: 21 mL.min-1.g-1
For compound 4 the middle estimate is 1.5-fold (0.18 log units) below the measured one, within the range that was stated.
By their numbers in this assay, from the lowest: compounds 1, 3 and 4 (each within the scatter of the next). At a limit, below all of these: compound 2.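

In this assay, placing 3-(dimethylcarbamoyl)-1-methyl-1H-pyrazol-5-yl in place of 1-methyl-1H-pyrazol-4-yl on this aromatic carbon of the shared core gives no change at the digits printed from compound 1 to compound 4 (within the scatter). Going by these compounds alone, this is the first step that isolates a change at this place, and it shows that the clearance reading stays level when the larger group enters, with its dimethylcarbamoyl and its different point of attachment on the pyrazole. No measurement shown bears on why the reading stays level.

Because the step changes both the point of attachment and the substitution of the pyrazole, it cannot say what each contributes alone, and 1-methyl-1H-pyrazol-5-yl without the dimethylcarbamoyl would separate the two. Within the data shown here, it also remains open whether the reading at this place stays level with a carboxylic acid or a primary amine in place of the dimethylcarbamoyl, since the one step here covers a single neutral amide.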